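The compounds below may be only part of what the source reports. "The series", "measured", "known", "first", "only" and "open" are said of these compounds alone.

Working notes on the series. In an assay on CHO cells with Alpha-2B adrenergic receptor (Homo sapiens) as the target (on this read-out higher numbers stand for larger maximal responses and lower numbers for smaller maximal responses), compound 3 `CCc1ccccc1OC(C)C1=NCCN1` gives 0.5; compound 1 `CC(Oc1ccccc1C=O)C1=NCCN1` gives 0.5, level with compound 3 at the digits shown, and compound 2 `C=COc1ccccc1OC(C)C1=NCCN1` gives 0.45. All three steps are within the scatter: no change at the digits printed from compound 1 to compound 3 (within the scatter), a number 0.050 lower from compound 1 to compound 2 (within the scatter) and a number 0.050 higher from compound 2 to compound 3 (within the scatter).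

Compound 4 `CC(Oc1ccccc1OC1CC1)C1=NCCN1` is not yet measured. The change from compound 3: cyclopropyloxy in place of ethyl on an aromatic carbon. The step bearing most on it is the reverse direction of a number 0.050 higher from compound 2 to compound 3 (within the scatter), an oxygen-linked group exchanged for ethyl on the same aromatic carbon, which stayed within the scatter, as did no change at the digits printed from compound 1 to compound 3 (within the scatter). No step beyond the scatter is therefore expected in this assay.

Compound 4 is accordingly estimated at 0.45, between 0.3 and 0.6, the expected step being a number 0.050 lower from compound 3 to compound 4 (within the scatter).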

Compound 4, intrinsic activity: the largest response reached, as a fraction of the reference agonist's: 0.6
Beside the measured number, compound 4's estimate is 0.15 below it; the range from low to high includes it.
By their numbers in this assay, from the lowest: compounds 2, 1, 3 and 4 (each within the scatter of the next, the first and the last beyond it).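

Among these compounds, at this aromatic carbon in this assay, cyclopropyl in place of vinyl on the oxygen gives a number 0.15 higher from compound 2 to compound 4 (beyond the scatter) and is the only step beyond the scatter, so the group carried on that oxygen can count. Against ethyl and formyl, cyclopropyloxy shows no such separation, with a number 0.10 higher from compound 3 to compound 4 (within the scatter) and a number 0.10 higher from compound 1 to compound 4 (within the scatter) both printed as within the scatter. Nothing measured here bears on the reason for the step.

Still open, on these data alone, is whether an amine, a carboxylic acid or a longer alkoxy chain at this aromatic carbon would extend the step. Also open, as far as these compounds go, is whether the step holds at other places on the aromatic ring.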